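A few compounds are considered here, and "the series" means these few. Any claim that something is new, unique, unknown or untested is made for them only; others in the source may bear on it.

Measured so far:

Compound 1, `O=C(O)c1[nH]c(-c2ccc(-c3nnn[nH]3)cc2)cc(=O)c1O`. In an ADME assay on NIH3T3 cells (Mus musculus) for cytotoxicity, read by MTT assay, with a stated time of 12 h (a higher number here means that more compound is tolerated, a lower number that less compound is tolerated), compound 1 gives > 800000 nM, which is a limit of the assay and not a number.

Compound 2, `Cc1cc(-c2nnn[nH]2)ccc1-c1cc(=O)c(O)c(C(=O)O)[nH]1`. In this assay compound 2 gives > 800000 nM, again a limit of the assay.

Within the data shown here, compound 2 therefore stands at the edge of what this assay can report: only a limit is known for it, and the one other value shown is a limit as well, as the limit of > 800000 nM in this assay, at which 2 of the 2 values shown sit, makes plain. Among the measured compounds shown here, the single measured step, a step that the two limits leave unreadable from compound 1 to compound 2, cannot be read for size, because both ends sit at that limit.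

Compound 3, `O=C(O)c1[nH]c(-c2ccc(-c3nnn[nH]3)cc2C(F)(F)F)cc(=O)c1O`, is the next compound, and it is not yet measured. It differs from compound 2 in one place: trifluoromethyl in place of methyl on an aromatic carbon.

For the measured compounds named here, the only step that bears on this change, from compound 1 to compound 2, gave nothing readable, so no direction and no size can be drawn from it. Compound 3 is therefore expected to stay where compound 2 stands, and the step of a number no higher from compound 2 to compound 3 (the limit leaves the size open) is estimated to be none beyond the scatter. For compound 3 the estimate in this assay is 800000 nM, with a range from 400000 nM to 1600000 nM.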

Compound 3, half-maximal cytotoxic concentration: > 800000 nM
Compound 3: no number, only a limit; the forecaster's own chance of this, stated with the estimate: 85%; the middle value sits exactly at the limit.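

Neither the step from compound 1 to compound 2 nor the steps to compound 3 can be read in this assay because all three compounds sit at one limit of the assay: the limit of > 800000 nM in this assay, at which 3 of the 3 values shown sit. The compounds shown leave open whether methyl or trifluoromethyl in place of hydrogen changes how much compound is tolerated.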